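A few compounds are considered here, and "the series" means these few. Any claim that something is new, unique, unknown or untested is made for them only; others in the source may bear on it.

Compound 1 `COc1nc2ccc(Br)cc2cc1C(c1ccccc1)n1cc(CCCCCO)nn1`: 12.9%
Compound 2 `CCCCCCCCc1cn(C(c2ccccc2)c2cc3cc(Br)ccc3nc2OC)nn1`: 2.27%
Compound 3 `COc1nc2ccc(Br)cc2cc1C(c1ccccc1)n1cc(-c2ccc(F)cc2)nn1`: 16.4%

These three compounds share one core and differ in a single group. In an ADME assay on PC-3 cells (Homo sapiens) for cytotoxicity, read by sulforhodamine B assay, with a stated time of 48 h, tested at 10 uM (a lower number here means less inhibition, a higher number more inhibition at the concentration tested (going by the name of the read-out)), compound 1 gives 12.9%, the second highest of the three numbers: compound 3 differs by a number 3.5 percentage points higher from compound 1 to compound 3 (within the scatter), while compound 2 differs by a number 10.6 percentage points lower from compound 1 to compound 2 (beyond the scatter). Compound 4 `COc1nc2ccc(Br)cc2cc1C(c1ccccc1)n1cc(-c2ccccc2C(F)(F)F)nn1` has not yet been measured. It carries 2-(trifluoromethyl)phenyl in place of 5-hydroxypentyl on an aromatic carbon. The measured step that bears on this is the one where 4-fluorophenyl took the place of 5-hydroxypentyl, from compound 1 to compound 3, which gave a number 3.5 percentage points higher from compound 1 to compound 3 (within the scatter). A similar outcome is expected here, so compound 4 is estimated to move by a number 3.1 percentage points higher from compound 1 to compound 4 (within the scatter), not beyond the scatter. The expected value for compound 4 is 16%, in a range from 5% to 30%.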

Compound 4, a percentage reported as inhibition, at one concentration (the size of the read-out at that concentration, not a potency): 17.4%
Estimate against measurement, compound 4: 1.4 percentage points below; the range from low to high includes it.
By their numbers in this assay, from the lowest: compound 2; then compounds 1, 3 and 4 (each within the scatter of the next).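

In this assay, placing 2-(trifluoromethyl)phenyl on this aromatic carbon gives a number 4.5 percentage points higher from compound 1 to compound 4 (within the scatter) and a number 1 percentage points higher from compound 3 to compound 4 (within the scatter), so the number stays level with those for both 5-hydroxypentyl and 4-fluorophenyl. Octyl alone stands apart, with a number 15.1 percentage points higher from compound 2 to compound 4 (beyond the scatter). A second, differently substituted phenyl group therefore gives a number within the scatter of the first. Nothing available explains these numbers. Still open, on these data alone, is whether an amine or a carboxylic acid on this carbon would stay level with these groups or fall towards octyl.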